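Swapping methyl for chloro: tolerance on Vero cells

A few compounds are considered here, and "the series" means these few. Any claim that something is new, unique, unknown or untested is made for them only; others in the source may bear on it.

Measured compounds in an ADME assay on Vero cells (Chlorocebus sabaeus) for cytotoxicity, read by MTT assay, with a stated time of 72 h; a lower number here means that less compound is tolerated, a higher number that more compound is tolerated:
compound 1, `O[C@@H]1Cc2ccccc2N[C@H](c2ccccc2)C1`, gives > 300000 nM; this is a limit of the assay.
compound 2, `COc1cccc([C@@H]2C[C@H](O)Cc3ccccc3N2)c1`, gives > 300000 nM; this is a limit of the assay.
compound 3, `Cc1cccc([C@@H]2C[C@H](O)Cc3ccccc3N2)c1`, gives > 300000 nM; this is a limit of the assay.

All three share one core and differ only in the group on the pendant aromatic ring. None of them returned a number in this assay, so compound 3 stands at a limit like the other two. The steps a step that the two limits leave unreadable from compound 1 to compound 2, a step that the two limits leave unreadable from compound 1 to compound 3 and a step that the two limits leave unreadable from compound 2 to compound 3 are therefore of unknown size; what is known is the limit of > 300000 nM in this assay, at which 3 of the 3 values shown sit.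

Compound 4, `O[C@@H]1Cc2ccccc2N[C@H](c2cccc(Cl)c2)C1`, carries the change (chloro in place of methyl on an aromatic carbon), on an aromatic carbon of a six-membered aromatic ring of carbon only, meta to a large group. For the measured compounds named here, no measured step shows what such a change does here, and every relative so far sat at the limit. The expectation for compound 4 in this assay is therefore that the step of a number no higher from compound 3 to compound 4 (the limit leaves the size open) stays within the scatter. Compound 4 is expected to give about 300000 nM, between 150000 nM and 600000 nM, most likely again reported as a limit.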

Compound 4, half-maximal cytotoxic concentration: 295000 nM
Compound 4: the middle estimate sits 1.0-fold (0.01 log units) above what was measured; the range from low to high includes it.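

In this assay, for the compounds shown here, compound 4, with chloro on an aromatic carbon meta to a large group, gives 295000 nM, the first real number in this set rather than a limit. Set against its relatives, this yields an at least 1.0-fold lower number from compound 3 to compound 4 (0.00 log units; that floor lies within the scatter), an at least 1.0-fold lower number from compound 2 to compound 4 (0.00 log units; that floor lies within the scatter) and an at least 1.0-fold lower number from compound 1 to compound 4 (0.00 log units; that floor lies within the scatter); each of these is only a floor, as the other compound in every pair stands at a limit. At this position, then, chloro gives a readable value, and that value lies level with the edge of what the assay reports, so no change in tolerance beyond the scatter can be claimed for the swap: the limit of > 300000 nM in this assay, at which 3 of the 4 values shown sit.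

From the compounds shown here alone, the true distance between compound 4 and compounds 1, 2 and 3 stays open, as does the question of whether any of these three would reach a readable value at all under this assay. Also open, going by these compounds, is what an amine, a carboxylic acid or a longer chain on the same aromatic carbon would do, and whether any such group would bring the number clearly down from that of compound 4.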